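This account rests on a few compounds, and the source may have more. Where it says the series, first, only, none or still open, it means among the compounds named here.

Measured so far in an ADME assay on Raji cells (Homo sapiens) for cytotoxicity, with a stated time of 72 h; on this read-out higher numbers stand for an effect only at larger amounts of compound and lower numbers for an effect already at smaller amounts:
compound 1 `Cc1cc(NC(=O)Nc2ccc(F)c(F)c2)c2ccccc2n1`: > 25000 nM
compound 2 `Cc1cc(NC(=O)Nc2cccc(F)c2)c2ccccc2n1`: > 25000 nM
compound 3 `COc1ccc(NC(=O)Nc2cc(C)nc3ccccc23)cc1Cl`: > 25000 nM

Each of these entries is a limit of the assay and not a number. Compound 3 therefore has no position on a numerical scale, and the two other entries offer no number to compare it with. All that the data show is the limit of > 25000 nM in this assay, at which 3 of the 3 values shown sit.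

Compound 4 `COc1ccc(NC(=O)Nc2cc(C)nc3ccccc23)cc1F` departs from compound 3 at a single place: fluoro in place of chloro on an aromatic carbon. The new group of compound 4 sits ortho to a methoxy group and meta to a large group.

Among the measured compounds shown here, only one measured step bears on this change, and only loosely. It is a step that the two limits leave unreadable from compound 1 to compound 2, in which hydrogen stands in place of fluoro on an aromatic carbon. That is a different exchange, and it has no readable size to carry over. No step beyond the usual scatter is thus expected in this assay, and no direction can be favoured. The expected step is a step that the limit leaves unreadable from compound 3 to compound 4. Compound 4 is most likely to be reported only as a limit again. The estimate for compound 4 is 30000 nM. Its expected range runs from 15000 nM to 60000 nM.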

Compound 4, half-maximal effective concentration: > 25000 nM
Compound 4: a limit, no number (the forecaster's own chance of this, stated with the estimate: 85%); the middle value does not contradict the limit.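

In this assay compound 4 gives > 25000 nM, which is again a limit of the assay and not a number. Its steps from compound 1, compound 2 and compound 3 therefore cannot be read: the limit of > 25000 nM in this assay, at which 4 of the 4 values shown sit.

The compounds shown leave open at what concentration any of them would have an effect on these cells, and whether fluoro in place of chloro would then make a difference.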